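A few compounds are considered here, and "the series" means these few. Any claim that something is new, unique, unknown or untested is made for them only; others in the source may bear on it.

Measured so far in an ADME assay on NCM460 cells (Homo sapiens) for cytotoxicity, read by CCK-8 assay, with a stated time of 48 h; on this read-out lower numbers stand for stronger inhibition and higher numbers for weaker inhibition:
compound 1 `COc1ccc(/C=C\c2cc(OC)c(OC)c(OC)c2)cc1OCc1ccc(CN2CCCC[C@H]2C(=O)O)cc1` gives > 50000 nM, which is a limit of the assay and not a number.
compound 2 `COc1ccc(/C=C\c2cc(OC)c(OC)c(OC)c2)cc1OCc1ccc(CN2CCCC[C@@H]2C(=O)O)cc1` gives > 50000 nM, again a limit rather than a number.
compound 3 `COc1ccc(/C=C\c2cc(OC)c(OC)c(OC)c2)cc1OCc1ccc(CN2CC[C@H](O)C2)cc1` gives 51000 nM.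

Compound 2 thus stands at the upper limit of this assay, and only a limit is known for it. The steps a step that the two limits leave unreadable from compound 1 to compound 2 and a step that the limit leaves unreadable from compound 2 to compound 3 are unreadable in size due to the limit of > 50000 nM in this assay, at which 2 of the 3 values shown sit; the first of them, noted by the fact that compounds 1 and 2 differ only in the configuration as drawn, is a change of configuration only. Compound 4 `COc1ccc(/C=C\c2cc(OC)c(OC)c(OC)c2)cc1OCc1ccc(CNCCNC(C)=O)cc1` carries the change ((2-acetamidoethyl)amino in place of 2-carboxypiperidin-1-yl on a saturated chain carbon bound to an aromatic carbon). Going by the values given here, no measured step bears a readable size on this change, and every value shown sits at or close to the limit, so no step beyond the scatter is expected; the expected step is a number no higher from compound 2 to compound 4 (the limit leaves the size open). Compound 4 is estimated at 50000 nM, expected between 20000 nM and 150000 nM, most likely reported as a limit.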

Compound 4, half-maximal inhibitory concentration: 54000 nM
For compound 4 the middle estimate is 1.1-fold (0.03 log units) below the measured one; the range from low to high includes it.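

In this assay, a group with no ring at this place, (2-acetamidoethyl)amino, gives a readable number, and the comparison with the ring-bearing 3-hydroxypyrrolidin-1-yl is a 1.1-fold higher number from compound 3 to compound 4 (0.02 log units; within the scatter). At this saturated chain carbon bound to an aromatic carbon, swapping one group for the other therefore leaves the read-out unmoved beyond the scatter. The steps from compound 1 and compound 2 to compound 4 cannot be read: the limit of > 50000 nM in this assay, at which 2 of the 4 values shown sit.

From the compounds shown here alone, whether any group at this place gives a step beyond the scatter stays open. A primary amine or a longer chain ending in a carboxylic acid could test this in this assay.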